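Replacing an aryl with a cyclohexyl on a shared core

The source may hold more compounds than are shown below. What is called first, only, known or untested is meant among the compounds shown, and "the series" means these compounds.

Compound 1 `Fc1cnc(Nc2cc3[nH]c(-c4cccc(C(F)(F)F)c4)nc3cn2)c(F)c1` in a physicochemical assay for solubility, using the shake flask method, measured as kinetic solubility, with a stated time of 20 h, at pH 2; a lower number here means a less soluble compound, a higher number a more soluble compound: < 5000 nM
Compound 2 `FC(F)(F)c1ccc(Nc2cc3[nH]c(-c4cccc(C(F)(F)F)c4)nc3cn2)nc1`: < 5000 nM
Compound 3 `O=C(O)c1ccnc(Nc2cc3[nH]c(-c4cccc(C(F)(F)F)c4)nc3cn2)c1`: < 5000 nM

The reading of compound 2 in this assay is a limit of the method, not a number, and the readings of compound 1 and compound 3 are limits of the same kind (the limit of < 5000 nM in this assay, at which 3 of the 3 values shown sit). The steps a step that the two limits leave unreadable from compound 1 to compound 2, a step that the two limits leave unreadable from compound 1 to compound 3 and a step that the two limits leave unreadable from compound 2 to compound 3 therefore cannot be sized, and compound 2 stands at that limit without a measured place beneath it.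

Compound 4 `FC(F)(F)c1ccc(Nc2cc3[nH]c([C@H]4CC[C@H](C(F)(F)F)CC4)nc3cn2)nc1` differs from compound 2 by 4-(trifluoromethyl)cyclohexyl in place of 3-(trifluoromethyl)phenyl on an aromatic carbon. No measured step touches this position, so nothing shown gives the size or direction to expect in this assay.

Compound 4 is estimated at 2500 nM, within 500 nM to 5000 nM. The expected step that the limit leaves unreadable from compound 2 to compound 4 most likely leaves it at the limit.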

Compound 4, solubility: 200000 nM
Beside the measured number, compound 4's estimate is 80-fold (1.90 log units) below it; measured number above the stated range.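

In this assay, the change at this position gives an at least 40-fold higher number from compound 2 to compound 4 (1.60 log units; beyond the scatter). Among these compounds, the group on the aromatic carbon between the two ring nitrogen atoms can therefore move this reading, whereas the earlier steps, all on a nitrogen on an aromatic ring, cannot be read. Compound 4 is the only compound shown with a reading that is a number and not a limit: the limit of < 5000 nM in this assay, at which 3 of the 4 values shown sit.

From the compounds shown here alone, it remains open whether 4-(trifluoromethyl)cyclohexyl would give a similar step with the other groups of compound 1 and compound 3 on that nitrogen. Going by these compounds, it is also open how a cyclohexyl carrying an amine or a hydroxyl group in place of trifluoromethyl would read.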